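The source may hold more compounds than are shown below. What is called first, only, known or untested is meant among the compounds shown, and "the series" means these compounds.

Measured in a functional assay on MDA-MB-231 cells (Homo sapiens) for inhibition, read by MTT assay, with a stated time of 72 h; a lower number here means a stronger inhibitor, a higher number a weaker inhibitor:
- compound 1 `Nc1nc2cc(-c3nn(CCCC(=O)NO)c4ncnc(N)c34)ccc2o1`: 19500 nM
- compound 2 `Nc1ncnc2c1c(-c1cnc3[nH]ccc3c1)nn2CCCCC(=O)NO`: > 50000 nM (a limit)
- compound 3 `Nc1ncnc2c1c(-c1cnc3[nH]ccc3c1)nn2CCCCCC(=O)NO`: > 100000 nM (a limit)

Among the measured compounds shown here, compound 1 carries the only true number in this assay, as the other two values are limits. Compound 4 `Nc1nc2cc(-c3nn(CCCCC(=O)NO)c4ncnc(N)c34)ccc2o1` differs from compound 1 by (hydroxycarbamoyl)methyl in place of hydroxycarbamoyl on a saturated chain carbon, three bonds along the chain from an aromatic nitrogen. For the measured compounds named here, the one measured step with this exchange sits on another core, four bonds along the chain from an aromatic nitrogen: a step that the two limits leave unreadable from compound 2 to compound 3. It gives neither size nor direction, so no shift beyond the scatter is expected in this assay. The expected outcome is an estimated 1.2-fold lower number from compound 1 to compound 4 (0.09 log units; within the scatter). For compound 4 the estimate is 16000 nM, with a range of 4000 nM to 60000 nM.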

Compound 4, half-maximal inhibitory concentration: 21200 nM
Beside the measured number, compound 4's estimate is 1.3-fold (0.12 log units) below it, and the stated range covers the measured number.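

In this assay the change from 3-(hydroxycarbamoyl)propyl to 4-(hydroxycarbamoyl)butyl on the core of compound 1 now has a readable size, with no shift beyond the scatter: a 1.1-fold higher number from compound 1 to compound 4 (0.04 log units; within the scatter). The step between compound 2 and compound 3 cannot be read, as both values are limits. Nothing shown gives a cause for this flat step.

Open, as far as these compounds go, is whether a longer chain, or a carboxylic acid in place of the hydroxycarbamoyl end, would move the number beyond the scatter. Also open, from the compounds shown here alone, is whether the core of compound 2 would give a readable step.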